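Shortening the ester chain: compound 2 to compound 3

A few compounds are considered here, and "the series" means these few. Any claim that something is new, unique, unknown or untested is made for them only; others in the source may bear on it.

Of the compounds shown here, two have been measured so far: compound 1 `CCNC(=O)C1=C(C)NC(=O)NC1c1ccoc1` and compound 2 `CCC(CC)OC(=O)C1=C(C)NC(=O)NC1c1ccoc1`. In an assay on membranes from HeLa cells for displacement of a labelled ligand from adenosine receptor A3 (Homo sapiens), read by scintillation counting, with a stated time of 180 min, tested at 1 uM (on this read-out lower numbers stand for less inhibition and higher numbers for more inhibition at the one concentration tested (going by the name of the read-out)), compound 1 gives 1% and compound 2 gives 5%. Within the data shown here, of the two numbers compound 2 holds the highest, but the only measured step, a number 4 percentage points higher from compound 1 to compound 2 (within the scatter), lies within the scatter, so neither compound stands apart from the other.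

Compound 3 `CCC(C)OC(=O)C1=C(C)NC(=O)NC1c1ccoc1` has not been measured. It differs from compound 2 by hydrogen in place of methyl on a saturated chain carbon, two bonds along the chain from an oxygen next to a carbonyl group. Among the measured compounds shown here, no measured step touches this part of the molecule: the single step, a number 4 percentage points higher from compound 1 to compound 2 (within the scatter), concerns the group on the carbonyl carbon rather than the chain. With compound 2 low and nothing pointing either way, the expected step is a number 1 percentage points lower from compound 2 to compound 3 (within the scatter), none beyond the scatter. For compound 3 in this assay the estimate is 4%, expected to fall between -6% and 14%.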

Compound 3, a percentage reported as inhibition, at one concentration (the size of the read-out at that concentration, not a potency): 11%
Estimate against measurement, compound 3: 7 percentage points below, and the stated range covers the measured number.
By their numbers in this assay, from the lowest: compounds 1, 2 and 3 (each within the scatter of the next).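

Pentan-3-yl to sec-butyl is the first change shown on the ester chain itself, and in this assay it gives a number 6 percentage points higher from compound 2 to compound 3 (within the scatter): the loss of this one methyl does not separate the two esters. With sec-butoxy in place of ethylamino on the carbonyl carbon, the result is a number 10 percentage points higher from compound 1 to compound 3 (within the scatter); this step, like the one with (pentan-3-yl)oxy, does not separate an ester from the ethylamino compound. No measurement available here offers an explanation for these small differences.

Still open, as far as these compounds go, is whether a longer chain, a carboxylic acid or an amine on this carbonyl carbon would move the read-out beyond the scatter. With all three compounds close together at the one concentration tested, the effect of the chain at this position remains undefined.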